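The source may report more compounds than this note shows. Statements on the series, on what has been measured and on what is new or still open speak of the compounds shown alone.

Four compounds share one core, completed by a saturated chain that ends in an aromatic ring. Compound 1 `O=C(CCc1ccccc1)NNc1c(Cl)cncc1Cl` gives 650 nM in a functional assay on HEK293 cells for antagonist activity at P2X purinoceptor 7 (Homo sapiens), read by fluorescence, with a stated time of 2 h; a lower number here means a stronger inhibitor, a higher number a weaker inhibitor. Compound 2 `O=C(CCCc1ccccc1)NNc1c(Cl)cncc1Cl` gives 770 nM in this assay; the change is benzyl in place of phenyl on a saturated chain carbon, two bonds along the chain from a carbonyl carbon, and the step is a 1.2-fold higher number from compound 1 to compound 2 (0.07 log units; within the scatter). Compound 3 `O=C(CCCCCc1ccccc1)NNc1c(Cl)cncc1Cl` gives 1900 nM in this assay, the highest of the three numbers; the difference between the core of compound 1 and the core of compound 3 is not broken down here. Compound 4 `O=C(CCCCCCc1ccccc1)NNc1c(Cl)cncc1Cl` is not yet measured. It differs from compound 3 by benzyl in place of phenyl on a saturated chain carbon, five bonds along the chain from a carbonyl carbon, the same kind of change as from compound 1 to compound 2, but sitting five bonds rather than two bonds along the chain from a carbonyl carbon. Because compound 3 gives 1900 nM while compound 2 gives 770 nM, a further modest rise is expected, a step of a 1.6-fold higher number from compound 3 to compound 4 (0.20 log units; within the scatter) beside the earlier one. Compound 4 is therefore estimated at 3000 nM in this assay, most likely between 1500 nM and 6500 nM.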

Compound 4, half-maximal inhibitory concentration: 950 nM
For compound 4 the middle estimate is 3.2-fold (0.50 log units) above the measured one; the measured number lies below the stated range.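

Benzyl in place of phenyl on a saturated chain carbon, five bonds along the chain from a carbonyl carbon, gives a 2.0-fold lower number from compound 3 to compound 4 (0.30 log units; within the scatter) in this assay. Set beside the same change two bonds along the chain from a carbonyl carbon, the two steps cannot be told apart: the same change on two cores in this assay, a 1.2-fold higher number (0.07 log units; within the scatter) from compound 1 to compound 2 and a 2.0-fold lower number (0.30 log units; within the scatter) from compound 3 to compound 4, 2.4-fold (0.37 log units) apart, within the scatter of two such steps. The pair therefore gives no sign that the change acts differently on these two cores, but each step is itself within the scatter, so it shows neither a real effect of the change nor a rule for other cores.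

Still open, from the compounds shown here alone, is whether a longer chain would fit the same picture. The compounds shown also leave open how an amine or a carboxylic acid on the chain would read in this assay.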